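The source may hold more compounds than are shown below. What is called first, only, known or untested is meant among the compounds shown, and "the series" means these compounds.

Measured so far:
compound 1, `CCCCCc1ccc(C#Cc2c(-c3ccc(CCCCC)cc3)oc3nc(=O)n(Cc4cn(-c5ccccc5F)nn4)cc23)cc1`: 9000 nM
compound 2, `CCCCCc1ccc(C#Cc2c(-c3ccc(CCCCC)cc3)oc3nc(=O)n(Cc4cn(-c5ccc(Cl)cc5)nn4)cc23)cc1`: > 100000 nM

In a functional assay on HeLa cells (Homo sapiens) for antiproliferative activity, read by MTT assay, with a stated time of 72 h (a lower number here means a stronger inhibitor, a higher number a weaker inhibitor), compound 1 gives 9000 nM. For compound 2 this assay reports only a limit, > 100000 nM, and not a number; this is the limit of > 100000 nM in this assay, at which 1 of the 2 values shown sits, so compound 2 stands at the edge of what was measurable. Compound 3 `CCCCCc1ccc(C#Cc2c(-c3ccc(CCCCC)cc3)oc3nc(=O)n(Cc4cn(Cc5ccccc5)nn4)cc23)cc1` differs from compound 2 by benzyl in place of 4-chlorophenyl on an aromatic nitrogen. Going by the values given here, the only measured step at this ring nitrogen, an at least 11-fold higher number from compound 1 to compound 2 (1.04 log units; beyond the scatter), ended at that limit, and no measured step covers a benzyl there. Compound 3 is therefore expected to remain weak, with an at least 1.6-fold lower number from compound 2 to compound 3 (0.22 log units; that floor lies within the scatter). The estimate for compound 3 is 60000 nM, within a range from 9000 nM to 400000 nM.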

Compound 3, half-maximal inhibitory concentration: 73000 nM
Estimate against measurement, compound 3: 1.2-fold (0.09 log units) below, and the stated range covers the measured number.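

In this assay, the benzyl group gives this aromatic nitrogen a second real number, and an 8.1-fold higher number from compound 1 to compound 3 (0.91 log units; beyond the scatter) shows that 2-fluorophenyl keeps the lower number against benzyl as well. Against 4-chlorophenyl the change reads only as an at least 1.3-fold lower number from compound 2 to compound 3 (0.13 log units; that floor lies within the scatter), so no order can be stated between those two groups. Compound 2 has a limit and not a number: the limit of > 100000 nM in this assay, at which 1 of the 3 values shown sits.

The compounds shown leave open whether the fluorine of compound 1 matters at all, since an unsubstituted phenyl is absent. They also leave open how a 2-phenylethyl group or an amine-bearing chain would read on this nitrogen.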